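A Chlorophenoxy Tail in Place of Phenyl

The source may report more compounds than this note shows. Statements on the series, on what has been measured and on what is new or still open speak of the compounds shown alone.

Compound 3 `Cc1cc(C)c(NC(=O)C(C)(C)CCCCc2ccccc2)c2c1CC(C)(C)O2` carries a branched saturated chain ending in a phenyl group on the amide side of the shared core. In an assay for inhibition of acyl-CoA:cholesterol acyltransferase (Oryctolagus cuniculus), using microsomes (a higher number here means a weaker inhibitor, a lower number a stronger inhibitor), compound 3 gives 210 nM, the highest of the three numbers measured. Compound 1 `CCCCCCCCCCC(C)(C)C(=O)Nc1c(C)c([N+](=O)[O-])c(C)c2c1OC(C)(C)C2`, which bears a nitro group on its core and a long saturated chain, gives 36 nM in this assay, and compound 2 `CCCCCCCCCCCCCCCC(=O)Nc1c(C)cc(C)c2c1OC(C)(C)C2`, with an unbranched long chain, gives 26 nM; both lie beyond the scatter below compound 3. No pair among these compounds differs in only one place, so no single step can be read directly from the measured set.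

Compound 4 `Cc1cc(C)c(NC(=O)C(C)(C)CCCCOc2ccc(Cl)cc2)c2c1CC(C)(C)O2` differs from compound 3 in one place: 4-chlorophenoxy in place of phenyl on a saturated chain carbon, five bonds along the chain from a carbonyl carbon. Going by the values given here, whether this change helps is uncertain, since the measured compounds give no direct step of this kind. Still, the long-tailed compound 2 gives 26 nM in this assay, which points toward a longer tail being tolerated or favored. Compound 4 is therefore expected to show a step of a 2.1-fold lower number from compound 3 to compound 4 (0.32 log units; beyond the scatter) in this assay, a moderate move toward stronger inhibition that could still fall within the scatter. Compound 4 is estimated at 100 nM, with a likely range from 30 nM to 350 nM.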

Compound 4, half-maximal inhibitory concentration: 330 nM
Compound 4: middle estimate off by 3.3-fold (0.52 log units), on the low side; measured number inside the range.
By their numbers in this assay, from the lowest: compounds 2 and 1 (each within the scatter of the next); then compounds 3 and 4 (each within the scatter of the next).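

In this assay, going by these compounds alone, putting 4-chlorophenoxy in place of phenyl on a saturated chain carbon, five bonds along the chain from a carbonyl carbon, gives a 1.6-fold higher number from compound 3 to compound 4 (0.20 log units; within the scatter), the first direct reading of a change at this position. The entering group has 8 heavy atoms against 6 and adds one hydrogen-bond acceptor, along with an oxygen and a chlorine, yet the step does not separate the two compounds, so phenyl and 4-chlorophenoxy cannot be told apart here. No supporting evidence bears on this result, so the reading remains the bare step between the two compounds.

The compounds shown do not separate the contributions of the oxygen and the chlorine, and a plain phenoxy or a 4-chlorophenyl group in the same place would divide the change into its two parts. They also leave open how this position would respond to a different kind of group, such as an amine or a carboxylic acid, or to a longer chain carrying the same phenyl.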